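Swapping a methyl for dimethylamino on the shared core

The compounds below may be only part of what the source reports. "The series", "measured", "known", "first", "only" and "open" are said of these compounds alone.

Of the compounds shown here, two built on the same core have been tested in an assay on isolated protein for inhibition of activin receptor type-2A (Homo sapiens), read by 33P incorporation, with a stated time of 20 min, in the presence of a further agent that is not named here; a higher number here means a weaker inhibitor, a lower number a stronger inhibitor. Compound 1, with the structure `CCc1nc2c(-c3ccnc(OC)c3)cnn2cc1OC`, gives 960 nM. Compound 2, with the structure `COc1cc(-c2cnn3cc(OC)c(C)nc23)ccn1`, gives 1200 nM. Among the measured compounds shown here, compound 2 holds the highest of these two numbers, but its only neighbour is compound 1, and the step of a 1.3-fold higher number from compound 1 to compound 2 (0.10 log units; within the scatter) is within the scatter, so the two are not distinguishable.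

Compound 3, with the structure `COc1cc(-c2cnn3cc(OC)c(N(C)C)nc23)ccn1`, has not been measured. It differs from compound 2 in one place: dimethylamino in place of methyl on an aromatic carbon. For the measured compounds named here, no measured step exchanges a methyl for a dimethylamino group anywhere, so there is no direct precedent. Going by the values given here, the one step available, from compound 1 to compound 2, only shortens a chain at this same ring position and leaves the number within the scatter. The expectation is therefore a modest step, a 1.2-fold lower number from compound 2 to compound 3 (0.08 log units; within the scatter), with no firm direction. Compound 3 is estimated at 1000 nM in this assay, within a range of 250 nM to 4000 nM.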

Compound 3, half-maximal inhibitory concentration: 3000 nM
Estimate against measurement, compound 3: 3.0-fold (0.48 log units) below, and the stated range covers the measured number.
By their numbers in this assay, from the lowest: compounds 1 and 2 (each within the scatter of the next); then compound 3.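

In this assay this position turns out to be able to move the number beyond the scatter: dimethylamino in place of methyl gives a 2.5-fold higher number from compound 2 to compound 3 (0.40 log units; beyond the scatter) and dimethylamino in place of ethyl gives a 3.1-fold higher number from compound 1 to compound 3 (0.49 log units; beyond the scatter) on the same aromatic carbon. The earlier pair showed only that methyl and ethyl here cannot be told apart, which left it unclear whether this carbon responds to a change at all; now a weaker inhibitor results with dimethylamino than with either of those groups, though both steps are modest in size. Nothing available here explains why the number rises with this group.

The compounds shown leave open whether the rise belongs to the nitrogen itself or to the two methyl groups it carries, a question that a primary amine or a methylamino group at this position could help to separate. They also leave open whether a longer chain such as propyl would stay level with methyl and ethyl, and whether any group here can bring the number down.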